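A few compounds are considered here, and "the series" means these few. Any claim that something is new, unique, unknown or untested is made for them only; others in the source may bear on it.

Measured so far in a functional assay on PC-3 cells (Homo sapiens) for cytotoxicity, read by MTT assay, with a stated time of 48 h; on this read-out lower numbers stand for stronger inhibition and higher numbers for weaker inhibition: compound 1 `O=C(CCl)N1N=C(c2cc3ccccc3oc2=O)CC1c1ccccc1`, 2980 nM; compound 2 `O=c1oc2ccccc2cc1C1=NN(S(=O)(=O)c2ccc([N+](=O)[O-])cc2)C(c2ccccc2)C1`, 46600 nM; compound 3 `Cc1ccc(S(=O)(=O)N2N=C(c3cc4ccccc4oc3=O)CC2c2ccccc2)cc1`, 48600 nM.

Compound 3 holds the highest number of the three. Compound 2 and compound 3 lie within the scatter of each other (a 1.0-fold higher number from compound 2 to compound 3 (0.02 log units; within the scatter)), while compound 1 sits far lower (a 16-fold higher number from compound 1 to compound 3 (1.21 log units; beyond the scatter)).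

Compound 4 `O=C(CNC1CC1)N1N=C(c2cc3ccccc3oc2=O)CC1c1ccccc1` is not yet measured. It differs from compound 3 by ((cyclopropylamino)methyl)carbonyl in place of (4-methylphenyl)sulfonyl on an amine nitrogen in a ring. The step that bears on this change is a 16-fold higher number from compound 1 to compound 3 (1.21 log units; beyond the scatter), a large one, with the sulfonyl on that ring nitrogen giving the higher number. Compound 4 returns to a carbonyl on that nitrogen, as in compound 1, so a large step down in this assay is expected, roughly reversing that move. For the measured compounds named here, the cyclopropylamino part has no precedent among the measured compounds, which widens the range. Compound 4 is expected near 4000 nM, between 1500 nM and 12000 nM, an expected step of a 12-fold lower number from compound 3 to compound 4 (1.08 log units; beyond the scatter).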

Compound 4, half-maximal inhibitory concentration: 28500 nM
For compound 4 the middle estimate is 7.1-fold (0.85 log units) below the measured one, outside the stated range (above it).
By their numbers in this assay, from the lowest: compound 1; then compounds 4, 2 and 3 (each within the scatter of the next).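

In this assay a carbonyl on the amine nitrogen in a ring is not enough on its own to give the low number of compound 1, since ((cyclopropylamino)methyl)carbonyl in place of (4-methylphenyl)sulfonyl stays within the scatter (a 1.7-fold lower number from compound 3 to compound 4 (0.23 log units; within the scatter)). The group on the saturated chain carbon bound to the carbonyl carbon also matters, with cyclopropylamino in place of chloro giving a modest step (a 9.6-fold higher number from compound 1 to compound 4 (0.98 log units; beyond the scatter)).

Open, going by these compounds, is whether bromo, a hydroxyl or a plain methyl on that chain carbon would stay near compound 1 or compound 4. No evidence at hand gives a cause for either step.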